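Swapping the aryl group on a triazole in a spiro-fused scaffold

The source may hold more compounds than are shown below. What is called first, only, known or untested is meant among the compounds shown, and "the series" means these compounds.

Compound 1, `Cc1ccc(C)c(-n2nncc2CN2C(=O)C3(C(C#N)=C(N)Oc4c3c3nc5ccccc5nc3c3ccccc43)c3ccccc32)c1`: in a functional assay on HepG2 cells (Homo sapiens) for antiproliferative activity, read by MTT assay, with a stated time of 48 h (on this read-out higher numbers stand for weaker inhibition and lower numbers for stronger inhibition), compound 1 gives > 50000 nM, which is a limit of the assay, not a number.
Compound 2, `COc1ccc(-n2nncc2CN2C(=O)C3(C(C#N)=C(N)Oc4c(N)cc5nc6ccccc6nc5c43)c3ccccc32)cc1`: in this assay compound 2 gives > 50000 nM, again a limit of the assay.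

Both values shown reach the same boundary, so compound 2 stands at the limit of > 50000 nM in this assay, at which 2 of the 2 values shown sit, and no real difference between the two measured compounds can be read from this. Within the data shown here, no step between measured compounds is available, so there is no measured pattern to lean on.

Compound 3, `N#CC1=C(N)Oc2c(N)cc3nc4ccccc4nc3c2C12C(=O)N(Cc1cnnn1-c1c(Cl)cc(Cl)cc1Cl)c1ccccc12`, is the next compound in line. It differs from compound 2 in one place: 2,4,6-trichlorophenyl in place of 4-methoxyphenyl on an aromatic nitrogen. The change alters only the group on the aromatic nitrogen while the shared core stays as it is.

Given that compound 2 sits at a limit, the step from compound 2 to compound 3 is expected to be a step that the limit leaves unreadable from compound 2 to compound 3, meaning no movement beyond the scatter that can be recognised from a limit. Compound 3 is therefore expected to give 60000 nM in this assay, with a range from 20000 nM to 150000 nM, and most likely the assay will again report only a limit.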

Compound 3, half-maximal inhibitory concentration: 37800 nM
For compound 3 the middle estimate is 1.6-fold (0.20 log units) above the measured one; the range from low to high includes it.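

In this assay, compound 3, with 2,4,6-trichlorophenyl on the aromatic nitrogen, is the only compound shown that returns a real number rather than a value at the assay's boundary: the limit of > 50000 nM in this assay, at which 2 of the 3 values shown sit.

Replacing 4-methoxyphenyl with 2,4,6-trichlorophenyl gives an at least 1.3-fold lower number from compound 2 to compound 3 (0.12 log units; that floor lies within the scatter). This figure is only a floor: the true value of compound 2 lies hidden behind its limit, so the real step could be no more than scatter or could be considerably larger. The new information is therefore modest: the group on this nitrogen can be changed with the shared core held constant and the result can fall within the range the assay reads, but a real gain in activity is not established.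

As far as these compounds go, a single pair cannot show which feature of the new group matters, so it remains open whether 4-chlorophenyl or plain phenyl at this position would also give a readable number. From the compounds shown here alone, it is equally open how a group of another kind, such as an aminophenyl or a carboxylic acid on the phenyl ring, would behave on this same core.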